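This account rests on a few compounds, and the source may have more. Where it says the series, first, only, none or still open, it means among the compounds named here.

Going by the values given here, compound 2 `CN(C)C(=O)CCSc1nc2cc(Cl)ccc2o1` gives 2.7 mL/min/g in an ADME assay on microsomes from liver (Homo sapiens) for metabolic stability, read by LC-MS, using NADPH, with a stated time of 45 min, tested at 0.5 uM (a lower number here means slower removal, a higher number faster removal of the compound), the lower of the two numbers so far; compound 1 `O=C(CCSc1nc2cc(Cl)ccc2o1)N1CCCCC1` gives 10.7 mL/min/g. Among the compounds with values here, the only step in hand is a 4.0-fold lower number from compound 1 to compound 2 (0.60 log units; beyond the scatter), a modest drop on going from a ring amine to an open one. Compound 3 `CC1CCCN1C(=O)CCSc1nc2cc(Cl)ccc2o1` differs from compound 2 by 2-methylpyrrolidin-1-yl in place of dimethylamino on a carbonyl carbon, which restores a ring on the carbonyl carbon, as in compound 1. Given the size of a 4.0-fold lower number from compound 1 to compound 2 (0.60 log units; beyond the scatter), a partial reversal is expected. For compound 3 the expected step is a 2.2-fold higher number from compound 2 to compound 3 (0.35 log units; beyond the scatter). Compound 3 is estimated at 6 mL/min/g, within 3 mL/min/g to 13 mL/min/g.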

Compound 3, intrinsic clearance in a liver preparation (reported as CLH), per the amount of preparation that the assay uses: 8.5 mL/min/g
Compound 3: the middle estimate sits 1.4-fold (0.15 log units) below what was measured; the measured number falls inside the stated range.
By their numbers in this assay, from the lowest: compound 2; then compounds 3 and 1 (each within the scatter of the next).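

Putting 2-methylpyrrolidin-1-yl on the carbonyl carbon gives a 3.1-fold higher number from compound 2 to compound 3 (0.50 log units; beyond the scatter) in this assay and so dimethylamino now stands apart from two ring amines, not one. The two rings themselves are not separated, with a 1.3-fold lower number from compound 1 to compound 3 (0.10 log units; within the scatter) as the step between them. Nothing measured here gives a reason for either step.

Still open, on these data alone, is whether the ring or the methyl goes with the higher number, which plain pyrrolidin-1-yl would address. Also open, as far as these compounds go, is how an open amine such as diethylamino or a ring such as morpholin-4-yl behaves on the same carbonyl carbon.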